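From 3-methylbenzyl to 2-methoxybenzyl at the assay limit

A few compounds are considered here, and "the series" means these few. Any claim that something is new, unique, unknown or untested is made for them only; others in the source may bear on it.

Measured in a functional assay on B16 cells (Mus musculus) for antiproliferative activity, with a stated time of 72 h; on this read-out higher numbers stand for weaker inhibition and lower numbers for stronger inhibition:
- compound 1 `OC[C@H]1O[C@@H](n2cnc3c(NCc4ccccc4F)ncnc32)[C@H](O)[C@@H]1O` gives > 166000 nM as a limit
- compound 2 `OC[C@H]1O[C@@H](n2cnc3c(NCc4cccc(Br)c4)ncnc32)[C@H](O)[C@@H]1O` gives > 166000 nM as a limit
- compound 3 `Cc1cccc(CNc2ncnc3c2ncn3[C@@H]2O[C@H](CO)[C@@H](O)[C@H]2O)c1` gives > 166000 nM as a limit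

Compound 3 gives no number, only a limit, and it stands with the whole set at the limit of > 166000 nM in this assay, at which 3 of the 3 values shown sit, in these notes. The next change leads to compound 4 `COc1ccccc1CNc1ncnc2c1ncn2[C@@H]1O[C@H](CO)[C@@H](O)[C@H]1O` and is 2-methoxyphenyl in place of 3-methylphenyl on a saturated chain carbon bound to a nitrogen on an aromatic ring in full. Put in words, 2-methoxyphenyl comes in place of 3-methylphenyl on a saturated chain carbon bound to a nitrogen on an aromatic ring.

Among the measured compounds shown here, three measured steps bear on this change. They are a step that the two limits leave unreadable from compound 1 to compound 3 for the 3-methylphenyl group, a step that the two limits leave unreadable from compound 1 to compound 2 for the exchange of one substituted phenyl for another, and a step that the two limits leave unreadable from compound 2 to compound 3 for a swap on the same ring. None of them gives a size to carry over. The expectation therefore rests on compound 3 at > 166000 nM as a limit, with no step beyond the scatter expected. The expected step is a number no higher from compound 3 to compound 4 (the limit leaves the size open) in this assay and has no favoured direction. The estimate for compound 4 is 166000 nM (expected range 70000 nM to 400000 nM), and a further limit is the likeliest report.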

Compound 4, half-maximal inhibitory concentration: > 166000 nM
Compound 4 ended at the assay's limit (the forecaster's own chance of this, stated with the estimate: 85%); the middle value sits exactly at the limit.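

The steps from compound 3, compound 2 and compound 1 to compound 4 cannot be read, as each joins two limits in this assay. The series stands at a single limit: the limit of > 166000 nM in this assay, at which 4 of the 4 values shown sit. The compounds shown leave open whether these substituted benzyl groups on the shared core differ at all in this assay, and in which direction.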